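This account rests on a few compounds, and the source may have more. Where it says the series, first, only, none or still open, it means among the compounds named here.

Notes on the series. Compound 1 `Fc1ccc(Oc2ccc3c(NCCCNCc4ccco4)ccnc3c2)cc1` is the reference point. Among the measured compounds shown here, in an ADME assay on HepG2 cells (Homo sapiens) for cytotoxicity, read by luminescence, CellTiter-Glo and ATP content, with a stated time of 72 h (a lower number here means that less compound is needed, a higher number that more compound is needed for the effect), compound 1 gives 16000 nM and stands highest of the two numbers measured so far, with compound 2 nearest. Compound 2 `COc1cccc(CNCCCNc2ccnc3cc(Oc4ccc(F)cc4)ccc23)c1O` gives 11000 nM in this assay. For the measured compounds named here, the one measured step, a 1.5-fold lower number from compound 1 to compound 2 (0.16 log units; within the scatter), concerns the group carried on a saturated chain carbon bound to an amine nitrogen and lies within the scatter.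

Compound 3 `COc1ccc(Oc2ccc3c(NCCCNCc4ccco4)ccnc3c2)cc1` is not yet measured. Its change from compound 1: methoxy in place of fluoro on an aromatic carbon. Going by the values given here, no measured step touches this aromatic carbon of the six-membered aromatic ring of carbon only, so nothing measured bears directly on the change. Among the compounds with values here, the single step at hand, from compound 1 to compound 2, was within the scatter, and the two measured numbers lie within the scatter of each other. On this footing no step beyond the scatter is expected in this assay in either direction, and the expected step of no change at the digits printed from compound 1 to compound 3 (within the scatter) rests on that alone. Compound 3 is estimated at 16000 nM in this assay, with a range from 7000 nM to 36000 nM.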

Compound 3, half-maximal effective concentration: 5300 nM
Compound 3: the middle estimate sits 3.0-fold (0.48 log units) above what was measured; measured number below the stated range.
By their numbers in this assay, from the lowest: compound 3; then compounds 2 and 1 (each within the scatter of the next).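

Working notes on the step. In this assay, among the compounds shown here, a 3.0-fold lower number from compound 1 to compound 3 (0.48 log units; beyond the scatter) is the first step to lie beyond the scatter, and it arises from the change of 4-fluorophenoxy to 4-methoxyphenoxy, not from the group on the saturated chain carbon. For the compounds shown here, this aromatic carbon, para to a large group, is therefore a place where a single replacement does move the number, here towards less compound needed for the effect, whereas the one earlier step left the number within the scatter. The step is modest and rests on this one pair, and no measurement at hand bears on what lies behind it.

Still open, as far as these compounds go, is whether the step belongs to methoxy in particular or would also appear with ethoxy, chloro, hydroxy or an amine on the same aromatic carbon. Going by these compounds alone, also open is whether methoxy in place of fluoro gives a similar step when the chain carries the 2-hydroxy-3-methoxyphenyl group of compound 2 instead of furan-2-yl, or when a longer chain replaces the one shared by these compounds.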